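Inverting both stereocentres of compound 1

This account rests on a few compounds, and the source may have more. Where it says the series, first, only, none or still open, it means among the compounds named here.

Measured in a functional assay on QGY cells (Homo sapiens) for cytotoxicity, read by MTT assay, with a stated time of 48 h; a higher number here means a weaker inhibitor, a lower number a stronger inhibitor:
compound 1 `COc1cc([C@H]2C[C@]2(CO)C(=O)Nc2ccccc2Cl)cc(OC)c1OC`: 40700 nM
compound 2 `CCOC(=O)[C@]1(C(=O)Nc2ccccc2Cl)C[C@@H]1c1cc(OC)c(OC)c(OC)c1`: 34700 nM
compound 3 `COc1cc([C@H]2C[C@]2(CO)C(=O)Nc2ccccc2)cc(OC)c1OC`: > 100000 nM (a limit of the assay, not a number)

In this assay the number for compound 1 stands level with that of compound 2, with a 1.2-fold lower number from compound 1 to compound 2 (0.07 log units; within the scatter) between them. The only other entry, for compound 3, is a limit. Compound 4 (`COc1cc([C@@H]2C[C@@]2(CO)C(=O)Nc2ccccc2Cl)cc(OC)c1OC`) is the compound still to be measured, and its comparison with compound 1 reads as follows (the two compounds have the same atoms and bonds and differ only in configuration as drawn: 2 of 2 stereo elements differ (all stereocentres are inverted: mirror images); a stereocentre at a saturated ring carbon is drawn R in compound 1 and S in compound 4; a stereocentre at a saturated ring carbon is drawn S in compound 1 and R in compound 4).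

Two measured steps start from compound 1, a 1.2-fold lower number from compound 1 to compound 2 (0.07 log units; within the scatter) for ethoxycarbonyl in place of hydroxymethyl on a saturated ring carbon and an at least 2.4-fold higher number from compound 1 to compound 3 (0.39 log units; beyond the scatter) for hydrogen in place of chloro on an aromatic carbon. Both exchange a group and keep the configuration as drawn, so neither measures an inversion and they bear on this change only indirectly. The expectation is therefore a step no larger than the scatter, leaning slightly toward a higher number, with a wide range around it. The expected step is a 1.2-fold higher number from compound 1 to compound 4 (0.09 log units; within the scatter) by this estimate. In this assay compound 4 is expected at 50000 nM with an estimated range from 15000 nM to 100000 nM overall.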

Compound 4, half-maximal inhibitory concentration: 24500 nM
Beside the measured number, compound 4's estimate is 2.0-fold (0.31 log units) above it, within the range that was stated.
By their numbers in this assay, from the lowest: compounds 4, 2 and 1 (each within the scatter of the next). At a limit, above all of these: compound 3.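

In this assay the inversion of both stereocentres gives a 1.7-fold lower number from compound 1 to compound 4 (0.22 log units; within the scatter), so this read-out does not separate the two mirror images. The earlier compounds all kept one configuration as drawn and spoke only to exchanges of groups, so this is the first pair shown to bear on configuration at these two saturated ring carbons, and nothing else varies within it: the fact that compounds 1 and 4 differ only in the configuration as drawn. Set beside the step for hydrogen in place of chloro on an aromatic carbon, an at least 2.4-fold higher number from compound 1 to compound 3 (0.39 log units; beyond the scatter), the complete inversion does not move the number beyond the scatter, while that exchange does.

Going by these compounds, compound 3 gives > 100000 nM, a limit and not a number, so the full size of the loss of chloro stays unknown, in this configuration as in the inverted one: the limit of > 100000 nM in this assay, at which 1 of the 4 values shown sits. Also open, on these data alone, are what inverting just one of the two stereocentres would give, and whether a carboxylic acid or an amine in place of hydroxymethyl, or bromo in place of chloro, would leave the number in this range.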